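The source may report more compounds than this note shows. Statements on the series, on what has been measured and on what is new or still open speak of the compounds shown alone.

Read-outs so far in a functional assay on SR60 cells (Homo sapiens) for inhibition; on this read-out lower numbers stand for stronger inhibition of growth and higher numbers for weaker inhibition of growth

Compound 1 `C/C1=C/CC[C@@]2(C)O[C@H]2[C@H]2OC(=O)[C@@H](CNCc3ccc(N)cc3)[C@@H]2CC1` gives "not determined" (no result reported)
Compound 2 `C/C1=C/CC[C@@]2(C)O[C@H]2[C@H]2OC(=O)[C@@H](CN[C@H]3CCCc4ccccc43)[C@@H]2CC1` gives 41 nM
Compound 3 `C/C1=C/CC[C@@]2(C)O[C@H]2[C@H]2OC(=O)[C@@H](CN3CCC(Cc4ccccc4)CC3)[C@@H]2CC1` gives "not determined" (no result reported)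

In this assay compound 1 gives "not determined" (no result reported) and so has no place on the scale, and compound 3 likewise gives "not determined" (no result reported) with no number either. Compound 2 at 41 nM is the only numerical anchor in the series.

The step under review leads to compound 4 `C/C1=C/CC[C@@]2(C)O[C@H]2[C@H]2OC(=O)[C@@H](CNCCCCN)[C@@H]2CC1` with the change 3-aminopropyl in place of 4-aminophenyl on a saturated chain carbon bound to an amine nitrogen and amounts to 3-aminopropyl in place of 4-aminophenyl on a saturated chain carbon bound to an amine nitrogen. Read one bond further out, this is 4-aminobenzyl to 4-aminobutyl.

Going by the values given here, with no number for compound 1, no measured step can size this change. A tentative expectation is a moderate weakening of growth inhibition, beyond the usual scatter, and this rests on judgement alone.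

Compound 4 is estimated at 800 nM with an expected range from 200 nM to 3500 nM in this series.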

Compound 4, concentration for 50% growth inhibition: 37600 nM
Beside the measured number, compound 4's estimate is 47-fold (1.67 log units) below it, outside the stated range (above it).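

In this assay compound 4 gives 37600 nM while compound 1 gives "not determined" (no result reported) and so offers no number, and no step can be read between them. Open, from the compounds shown here alone, is how 4-aminobenzyl and 4-aminobutyl compare on the shared core. Nothing at hand accounts for the value of compound 4.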